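Widening a Ring on the Aromatic Nitrogen

The source may report more compounds than this note shows. Statements on the series, on what has been measured and on what is new or still open speak of the compounds shown alone.

Three compounds have been measured:
compound 1 `CC/N=C(\N)Nc1ccc(Sc2ccc(OC)cc2)cc1` gives 251 nM
compound 2 `FC(F)(F)c1ccc(Sc2ccc(NC3=NCCN3)cc2)cc1` gives 50.1 nM
compound 3 `COc1ccc(Sc2ccc(NC3=NC(C)CN3)cc2)cc1` gives 63.1 nM

These numbers come from an assay (Rattus norvegicus) for binding affinity to prostacyclin receptor (Homo sapiens), read by radioligand binding; a higher number here means a weaker inhibitor, a lower number a stronger inhibitor. Compound 3 stands second highest of the three: compound 2 is within the scatter of it, while compound 1 sits well above it. Within the data shown here, the one step that can be counted, a 4.0-fold lower number from compound 1 to compound 3 (0.60 log units; beyond the scatter), exchanged an open chain for a five-membered ring on the nitrogen attached to the aromatic ring, and it lowered the number.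

Compound 4 `COc1ccc(Sc2ccc(NC3=NCCCCN3)cc2)cc1` differs from compound 3 by a group of 7 heavy atoms (5 carbon, 2 nitrogen; one seven-membered non-aromatic ring with 2 hetero atoms) in place of a group of 6 heavy atoms (4 carbon, 2 nitrogen; one five-membered non-aromatic ring with 2 hetero atoms), on a nitrogen on an aromatic ring. Among the measured compounds shown here, no measured step shows what widening this ring from five to seven members does; the earlier step only shows that closing the ring helped. With nothing in the data pointing either way, the expectation for compound 4 in this assay is a number near that of compound 3, with the step of a 1.6-fold higher number from compound 3 to compound 4 (0.20 log units; within the scatter) expected to lie within the scatter. The estimate for compound 4 is 100 nM, expected to fall between 30 nM and 400 nM.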

Compound 4, inhibition constant: 1260 nM
Compound 4: the middle estimate sits 13-fold (1.10 log units) below what was measured; measured number outside the range, above it.
By their numbers in this assay, from the lowest: compounds 2 and 3 (each within the scatter of the next); then compound 1; then compound 4.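

In this assay this place, on a nitrogen on an aromatic ring, proves highly sensitive to the ring it carries: the seven-membered non-aromatic ring with 2 hetero atoms, in place of the five-membered one, gives a 20-fold higher number from compound 3 to compound 4 (1.30 log units; beyond the scatter). Closing a ring is therefore not enough to lower the number, since the open-chain group and the seven-membered ring compare as a 5.0-fold higher number from compound 1 to compound 4 (0.70 log units; beyond the scatter), the opposite direction from the step to the five-membered ring. Nothing available explains this reversal.

Still open, going by these compounds, is whether a six-membered non-aromatic ring with 2 hetero atoms would fall closer to compound 3 or to compound 4. Also open, on these data alone, is whether the seven-membered ring would give the same result with trifluoromethyl in place of the methoxy group.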